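Ethoxy in Place of 4-Chlorophenyl: Expectation for Compound 3

A few compounds are considered here, and "the series" means these few. Any claim that something is new, unique, unknown or untested is made for them only; others in the source may bear on it.

Measured compounds:
compound 1, `CC(C)(C)n1cc2c(n1)C(=O)CC1(CCN(C(=O)c3cc(-c4ccc(Cl)cc4)nc4ccccc34)CC1)O2`, > 10000 nM
compound 2, `COc1ccc(-c2cc(C(=O)N3CCC4(CC3)CC(=O)c3nn(C(C)(C)C)cc3O4)c3ccccc3n2)cc1`, > 10000 nM

In a functional assay on MDA-MB-231 cells (Homo sapiens) for inhibition, read by MTT assay, with a stated time of 72 h (a lower number here means a stronger inhibitor, a higher number a weaker inhibitor), compound 1 gives > 10000 nM, which is a limit of the assay and not a number. Compound 2 gives > 10000 nM, again a limit rather than a number. For the measured compounds named here, the one measured step, a step that the two limits leave unreadable from compound 1 to compound 2, therefore cannot be read as a size, because both of its values sit at the limit of > 10000 nM in this assay, at which 2 of the 2 values shown sit. Compound 1 thus stands only at a limit, with no numbered value anywhere in this set to place it against.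

Compound 3, `CCOc1cc(C(=O)N2CCC3(CC2)CC(=O)c2nn(C(C)(C)C)cc2O3)c2ccccc2n1`, differs from compound 1 by ethoxy in place of 4-chlorophenyl on an aromatic carbon. Going by the values given here, no measured step touches the 4-chlorophenyl group itself; the only recorded change concerns a substituent on that group, and its size is unreadable. Among the compounds with values here, there is thus no evidence of any step in this assay that would move compound 3 away from where compound 1 stands. Compound 3 is expected to give about 15000 nM, within 5000 nM to 60000 nM, most probably reported again as a limit. The step that the limit leaves unreadable from compound 1 to compound 3 is estimated to lie within the usual scatter.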

Compound 3, half-maximal inhibitory concentration: > 10000 nM
Compound 3 ended at the assay's limit; the forecaster's own chance of this, stated with the estimate: 80%; the middle value lies beyond the limit too.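

In this assay, compound 3 sits with compound 1 and compound 2 at a limit rather than a number, so no step among these three compounds can be read: the limit of > 10000 nM in this assay, at which 3 of the 3 values shown sit.

The compounds shown leave open how strongly any of them inhibits in this assay, and whether ethoxy, 4-chlorophenyl or 4-methoxyphenyl on that aromatic carbon makes any difference.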